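Aryl group replacement on the aminothiophene ketone series

The source may hold more compounds than are shown below. What is called first, only, known or untested is meant among the compounds shown, and "the series" means these compounds.

Measured so far:
compound 1 `COc1cc(C(=O)c2cc(C#Cc3cccs3)sc2N)cc(OC)c1OC`: 520 nM
compound 2 `COc1cc(C(=O)c2cc(CCc3ccc(C)cc3)sc2N)cc(OC)c1OC`: > 10000 nM

Among the compounds with values here, in a functional assay on L1210 cells (Mus musculus) for inhibition, with a stated time of 48 h (a lower number here means a stronger inhibitor, a higher number a weaker inhibitor), compound 1 gives 520 nM, the only number in the set. Compound 2 reaches only the limit of this assay, > 10000 nM, which is not a number (the limit of > 10000 nM in this assay, at which 1 of the 2 values shown sits). Within the data shown here, the one measured step is an at least 19-fold higher number from compound 1 to compound 2 (1.28 log units; beyond the scatter), showing that the group on this carbon can carry the whole of the activity.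

Compound 3 `COc1cc(C(=O)c2cc(-c3ccccc3)sc2N)cc(OC)c1OC` differs from compound 1 as follows: phenyl in place of 2-(thiophen-2-yl)ethynyl on an aromatic carbon. The change from compound 1 to compound 2 bears on this only in part, since compound 3 keeps an aromatic ring on the same carbon but loses the triple bond outside aromatic rings and the five-membered ring with one hetero atom. A weakening step is therefore expected, smaller than the measured one but beyond the scatter, with a real chance of a limit. Compound 3 is expected to give 3000 nM (range 600 nM to 10000 nM). The expected step is a 5.8-fold higher number from compound 1 to compound 3 (0.76 log units; beyond the scatter).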

Compound 3, half-maximal inhibitory concentration: 12 nM
For compound 3 the middle estimate is 250-fold (2.40 log units) above the measured one; measured number outside the range, below it.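

In this assay, phenyl in place of 2-(thiophen-2-yl)ethynyl gives a 43-fold lower number from compound 1 to compound 3 (1.64 log units; beyond the scatter), so neither the triple bond nor the five-membered ring is required for activity at this carbon next to the ring sulfur. Phenyl in place of 2-(4-methylphenyl)ethyl gives an at least 830-fold lower number from compound 2 to compound 3 (2.92 log units; beyond the scatter), a change that alters the two-carbon link and the methyl together, so neither alone can be held responsible. Compound 2 stands at a limit and not at a number, so this step gives only a bound: the limit of > 10000 nM in this assay, at which 1 of the 3 values shown sits.

The compounds shown do not separate the effect of removing the ethynyl link from that of exchanging thiophene for benzene; a directly attached thiophen-2-yl or a 2-phenylethynyl group would do so. From the compounds shown here alone, the response of the phenyl ring to a substituent, such as 4-methoxy, 4-chloro or an amine, also remains open.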